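The compounds below may be only part of what the source reports. "The series", "measured", "known", "first", "only" and "open" are said of these compounds alone.

Compound 1 `C=CCc1cc(OC)c(OC(C)C(O[C@@H]2C[C@H](C)CC[C@H]2C(C)C)c2ccc(O)c(OC)c2)c(OC)c1` gives 28 nM in an assay on HEK293 cells for agonist activity at transient receptor potential cation channel subfamily M member 8 (Homo sapiens), read by fluorescence and calcium flux, with a stated time of 5 min; on this read-out lower numbers stand for an effect already at smaller amounts and higher numbers for an effect only at larger amounts of compound.
Compound 2 `C=CCc1cc(OC)c(O[C@H](C)[C@@H](OCC)c2ccc(O)c(OC)c2)c(OC)c1` gives 1150 nM.
Compound 3 `C=CCc1cc(OC)c(OC(C)C(OCCCCCCCCCC)c2ccc(O)c(OC)c2)c(OC)c1` gives 66 nM.

Compound 2 stands at the highest number of the three; compound 3 is nearest, compound 1 furthest. Going by the values given here, the one step between measured compounds, a 2.4-fold higher number from compound 1 to compound 3 (0.37 log units; beyond the scatter), swaps one group on the oxygen for another and says nothing about configuration. Compound 4 `C=CCc1cc(OC)c(O[C@H](C)[C@H](OCC)c2ccc(O)c(OC)c2)c(OC)c1` differs from compound 2 only in the way described: the two compounds have the same atoms and bonds and differ only in configuration as drawn: 1 of 2 stereo elements differ; a stereocentre at a saturated chain carbon is drawn S in compound 2 and R in compound 4. No measured pair here turns on a single stereocentre, so no shown step bears on this change, and neither its direction nor its size can be read from the data. Compound 4 is therefore expected near the number of compound 2, with a wide range and a step of a 1.2-fold lower number from compound 2 to compound 4 (0.06 log units; within the scatter); the estimate for compound 4 is 1000 nM, between 250 nM and 4000 nM.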

Compound 4, half-maximal effective concentration: 583 nM
Beside the measured number, compound 4's estimate is 1.7-fold (0.23 log units) above it, and the stated range covers the measured number.
By their numbers in this assay, from the lowest: compound 1; then compound 3; then compounds 4 and 2 (each within the scatter of the next).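

Changing the stereocentre at the saturated chain carbon, drawn S and then R, gives a 2.0-fold lower number from compound 2 to compound 4 (0.30 log units; within the scatter) in this assay. Going by these compounds alone, this is the first measured pair to turn on a single stereocentre, and at this position the change in configuration moves the number by no more than the scatter. The comparison is a clean one: the fact that compounds 2 and 4 differ only in the configuration as drawn.

Going by these compounds, it remains open whether configuration at this carbon matters as little with decyl or 2-isopropyl-5-methylcyclohexyl on the oxygen. On these data alone, how a benzyl group or a chain ending in an amine would read there also remains open.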